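The compounds below may be only part of what the source reports. "The series", "measured", "known", "first", "only" and "open" are said of these compounds alone.

Measured so far in a functional assay on RAW264.7 cells (Mus musculus) for inhibition, read by immunoassay, with a stated time of 12 h, tested at 30 uM; a lower number here means less inhibition, a higher number more inhibition at the concentration tested (going by the name of the read-out):
compound 1 `O=C1CC(c2ccccc2OCc2ccc(F)cc2)Oc2ccccc21` gives 45.2%
compound 2 `O=C1CC(c2ccccc2OCc2ccccc2)Oc2ccccc21` gives 93.2%
compound 3 `COc1ccccc1C1CC(=O)c2ccccc2O1` gives 37.3%

Compound 3 carries the lowest of the three numbers, but its gap to compound 1 sits within the scatter; only compound 2 stands clearly apart from it, as a number 55.9 percentage points lower from compound 2 to compound 3 (beyond the scatter) shows.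

Compound 4 `COCOc1ccccc1C1CC(=O)c2ccccc2O1` arises from compound 3 by methoxy in place of hydrogen on a saturated chain carbon bound to an oxygen on an aromatic ring. The change sits at the same place that was filled in compound 1 and compound 2, so both steps into compound 3 bear on it: the loss of phenyl there, a number 55.9 percentage points lower from compound 2 to compound 3 (beyond the scatter), was large, whereas the loss of 4-fluorophenyl there, a number 7.9 percentage points lower from compound 1 to compound 3 (within the scatter), moved nothing beyond the scatter. Filling this position has therefore given either a large gain or no change, with no case of a loss. Methoxy differs from both earlier entrants, so the expectation leans only to a modest rise, a number 10.7 percentage points higher from compound 3 to compound 4 (beyond the scatter), and is held loosely. For compound 4 the estimate in this assay is 48%, with a range from 28% to 72%.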

Compound 4, a percentage reported as inhibition, at one concentration (the size of the read-out at that concentration, not a potency): 35.2%
Estimate against measurement, compound 4: 12.8 percentage points above; the measured number falls inside the stated range.
By their numbers in this assay, from the lowest: compounds 4, 3 and 1 (each within the scatter of the next); then compound 2.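

In this assay, methoxy on a saturated chain carbon bound to an oxygen on an aromatic ring leaves the read-out unchanged against hydrogen (a number 2.1 percentage points lower from compound 3 to compound 4 (within the scatter)), so the earlier idea of a gain or no change now has a second no-change case, and this time the entering group carries no ring. The high number stays with phenyl alone (a number 58 percentage points lower from compound 2 to compound 4 (beyond the scatter)), while 4-fluorophenyl and methoxy cannot be told apart (a number 10 percentage points lower from compound 1 to compound 4 (within the scatter)), so filling this place does not by itself give a gain. No measured evidence bears on why these compounds differ in this way.

On these data alone, whether the high number needs an aromatic ring at this place stays open, and cyclohexyl in place of phenyl would address that. Equally open, as far as these compounds go, is whether fluoro alone goes against it, or whether chloro or methyl on the phenyl would do the same.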